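The compounds below may be only part of what the source reports. "The series", "measured", "known", "first", "only" and "open" are said of these compounds alone.

Two ribosyl triazoles have been measured in a functional assay on L1210 cells (Mus musculus); a higher number here means a weaker inhibitor, a lower number a stronger inhibitor. Compound 1 `NC(=O)c1cn([C@@H]2O[C@H](CO)[C@@H](O)[C@H]2O)nn1` carries a carbamoyl group on the triazole carbon. In this assay compound 1 reaches only the limit > 200000 nM. Compound 2 `OCc1cn([C@@H]2O[C@H](CO)[C@@H](O)[C@H]2O)nn1` bears a hydroxymethyl group in that place. In this assay compound 2 likewise reaches only the limit > 200000 nM. The step that the two limits leave unreadable from compound 1 to compound 2 therefore has no readable size or direction. Compound 2 thus stands at the edge of what this assay reports, sharing the position at which both values sit (the limit of > 200000 nM in this assay, at which 2 of the 2 values shown sit), and no number places it on a scale.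

Compound 3 `OC[C@H]1O[C@@H](n2cc(-c3ccccn3)nn2)[C@H](O)[C@@H]1O` differs from compound 2 by pyridin-2-yl in place of hydroxymethyl on an aromatic carbon. Among the compounds with values here, no measured step speaks directly to this change, and the one step that exists cannot be scaled because both of its ends are limits (the limit of > 200000 nM in this assay, at which 2 of the 2 values shown sit). Compound 3 is consequently expected to show a step that the limit leaves unreadable from compound 2 to compound 3 of no clear direction in this assay. Compound 3 is estimated at 300000 nM, within a range from 80000 nM to 1000000 nM, and most likely reported again only as a limit.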

Compound 3, half-maximal inhibitory concentration: 236000 nM
The estimate for compound 3 lay 1.3-fold (0.10 log units) above the measured number; low and high end bracket the measured number.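

No step to compound 3 can be read from compound 1 or compound 2, because those two compounds give only a limit and no number: the limit of > 200000 nM in this assay, at which 2 of the 3 values shown sit.

The compounds shown leave open whether pyridin-2-yl, hydroxymethyl and carbamoyl on that aromatic carbon differ at all in this assay, and by how much.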